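A benzyl swap on sulfur in a toxicity test

This account rests on a few compounds, and the source may have more. Where it says the series, first, only, none or still open, it means among the compounds named here.

Within the data shown here, in a toxicity assay on GES1 cells (Homo sapiens) for inhibition, read by MTT assay, with a stated time of 72 h (a lower number here means a stronger inhibitor, a higher number a weaker inhibitor), compound 3 `Cc1cc(N2CC[C@@H](C)[C@@H](N(C)c3ncnc4[nH]ccc34)C2)n2nc(SCc3cc(Cl)ccc3Cl)nc2n1` gives 87500 nM, the only true number so far. Compound 1 `Cc1cc(N2CC[C@@H](C)[C@@H](N(C)c3ncnc4[nH]ccc34)C2)n2nc(SCc3ccc(Cl)cc3)nc2n1` gives > 100000 nM, which is a limit of the assay. Compound 2 `C=CCSc1nc2nc(C)cc(N3CC[C@@H](C)[C@@H](N(C)c4ncnc5[nH]ccc45)C3)n2n1` gives > 100000 nM, again a limit. The series thus sits at the limit of > 100000 nM in this assay, at which 2 of the 3 values shown sit.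

Compound 4 `Cc1cc(N2CC[C@@H](C)[C@@H](N(C)c3ncnc4[nH]ccc34)C2)n2nc(SCc3ccc(Br)cc3)nc2n1` has 4-bromophenyl in place of 2,5-dichlorophenyl on a saturated chain carbon bound to a sulfur.

Compound 1, with its 4-chlorophenyl, is the closest measured relative of compound 4. The swaps at this place show an at least 1.1-fold lower number from compound 1 to compound 3 (0.05 log units; that floor lies within the scatter) and an at least 1.1-fold lower number from compound 2 to compound 3 (0.05 log units; that floor lies within the scatter), so neither gives reason to expect a real shift. The expected change is a 1.1-fold higher number from compound 3 to compound 4 (0.06 log units; within the scatter), nothing beyond the scatter. Compound 4 is estimated at 100000 nM, within a range of 60000 nM to 170000 nM.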

Compound 4, half-maximal inhibitory concentration: 55600 nM
For compound 4 the middle estimate is 1.8-fold (0.25 log units) above the measured one; measured number outside the range, below it.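

At this place, on a saturated chain carbon bound to a sulfur, compound 4 gives a second true number in this assay, and 4-bromophenyl in place of 2,5-dichlorophenyl gives a 1.6-fold lower number from compound 3 to compound 4 (0.20 log units; within the scatter). Bromo in place of chloro on an aromatic carbon gives an at least 1.7-fold lower number from compound 1 to compound 4 (0.25 log units; that floor lies within the scatter), and 4-bromophenyl in place of vinyl gives an at least 1.7-fold lower number from compound 2 to compound 4 (0.25 log units; that floor lies within the scatter). These last two steps are only floors, so none of the three is shown to pass the scatter, and they rest on a limit: the limit of > 100000 nM in this assay, at which 2 of the 4 values shown sit.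

Still open, from the compounds shown here alone, is whether an amine or a carboxylic acid in place of the 4-bromophenyl would move the number beyond the scatter.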